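Working notes: carbamoyl for ethyl, cytotoxicity expectation

This account rests on a few compounds, and the source may have more. Where it says the series, first, only, none or still open, it means among the compounds named here.

Measured so far in an ADME assay on BaF3 cells (Mus musculus) for cytotoxicity; a lower number here means that less compound is needed, a higher number that more compound is needed for the effect:
- compound 1 `CCCn1ncc2c(Nc3ccc(OC(F)(F)F)cc3)ncnc21`: compound 1 gives 6600 nM
- compound 2 `Cc1ccc(NC(=O)c2cccc(C(F)(F)F)c2)cc1C(=O)c1cc2c(Nc3ccc(OC(F)(F)F)cc3)ncnc2s1`: compound 2 gives 8900 nM
- compound 3 `CCn1cc2c(Nc3ccc(OC(F)(F)F)cc3)ncnc2n1`: compound 3 returns a limit, not a number, > 10000 nM

Compound 1 holds the lowest of the two numbers in this assay; compound 2 sits close by, and the gap between them is within the scatter, so no order between the two can be drawn. For compound 3 only the limit of > 10000 nM in this assay, at which 1 of the 3 values shown sits, is known.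

Compound 4 `NC(=O)Cn1ncc2c(Nc3ccc(OC(F)(F)F)cc3)ncnc21` differs from compound 1 in one place: carbamoyl in place of ethyl on a saturated chain carbon bound to an aromatic nitrogen. Read one bond further out, the change is propyl to carbamoylmethyl. Among the measured compounds shown here, no step between measured compounds mirrors this change, so the expected size rests on where compound 1 stands alone. A moderate rise in the number, somewhat beyond the scatter, is expected, meaning more compound needed for the effect.

The step from compound 1 to compound 4 is estimated as a 1.7-fold higher number from compound 1 to compound 4 (0.22 log units; within the scatter). Compound 4 is expected to give 11000 nM in this assay, with a range from 4500 nM to 28000 nM. Given (the limit of > 10000 nM in this assay, at which 1 of the 3 values shown sits), a limit-only read for compound 4 is a real possibility.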

Compound 4, half-maximal effective concentration: 3300 nM
The estimate for compound 4 lay 3.3-fold (0.52 log units) above the measured number, outside the stated range (below it).
By their numbers in this assay, from the lowest: compounds 4, 1 and 2 (each within the scatter of the next, the first and the last beyond it). At a limit, above all of these: compound 3.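

In this assay, carbamoyl in place of ethyl on a saturated chain carbon bound to an aromatic nitrogen gives a 2.0-fold lower number from compound 1 to compound 4 (0.30 log units; within the scatter). Among the compounds shown here, this is the first step readable at this place, and it shows that the hydrogen-bond donor and hydrogen-bond acceptor counted for carbamoyl, neither of which is counted for ethyl, bring no shift that can be separated from the scatter. Compound 4 also returns a number rather than a limit, although limits still occur among the values in this series: the limit of > 10000 nM in this assay, at which 1 of the 4 values shown sits.

A single step within the scatter gives no trend for this place, and it cannot show whether the amide hydrogen or the carbonyl matters to the read-out. From the compounds shown here alone, it remains open whether a carboxylic acid, an amine or a longer chain ending in carbamoyl at the same place would stay within the scatter of compound 1 or move the number clearly in either direction.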